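Halogen swap on the fluorinated arene of compound 2

The source may hold more compounds than are shown below. What is called first, only, known or untested is meant among the compounds shown, and "the series" means these compounds.

Measured so far:
compound 1 `CCC(CC)n1c(-c2ccc(OCc3c(-c4c(Cl)cccc4Cl)noc3C(C)C)cc2F)nc2ccc(C(=O)O)cc21`: > 10000 nM
compound 2 `CC(C)c1onc(-c2c(Cl)cccc2Cl)c1COc1ccc(-c2nc3ccc(C(=O)O)cc3n2CC2CCCCC2)c(F)c1`: 840 nM
compound 3 `CC(C)c1onc(-c2c(Cl)cccc2Cl)c1COc1ccc(-c2nc3ccc(C(=O)O)cc3n2C2CC2)cc1`: 3200 nM

All three were tested in an assay on HEK-293T cells for antagonist activity at vitamin D3 receptor (Homo sapiens), read by a luciferase reporter, with a stated time of 24 h; a higher number here means a weaker inhibitor, a lower number a stronger inhibitor. For compound 1 the result is a limit of the assay, not a number. Among the numbers shown, compound 2 stands lowest; compound 3 is nearest, with a higher number beyond the scatter, but the two differ in more than one place, so no single step connects them. Among the compounds with values here, the only single-place step measured, an at least 11-fold lower number from compound 1 to compound 2 (1.07 log units; beyond the scatter), concerns the group on the aromatic nitrogen and rests on (the limit of > 10000 nM in this assay, at which 1 of the 3 values shown sits).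

Compound 4 `CC(C)c1onc(-c2c(Cl)cccc2Cl)c1COc1ccc(-c2nc3ccc(C(=O)O)cc3n2CC2CCCCC2)c(Cl)c1` differs from compound 2 by chloro in place of fluoro on an aromatic carbon. Within the data shown here, no measured step touches this position. A step within the scatter is therefore expected, a 1.2-fold lower number from compound 2 to compound 4 (0.08 log units; within the scatter). Compound 4 is estimated at 700 nM, with a range of 250 nM to 2500 nM.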

Compound 4, half-maximal inhibitory concentration: 160 nM
Beside the measured number, compound 4's estimate is 4.4-fold (0.64 log units) above it, outside the stated range (below it).
By their numbers in this assay, from the lowest: compound 4; then compound 2; then compound 3. At a limit, above all of these: compound 1.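

In this assay, the halogen on this aromatic carbon is not a silent feature: chloro in place of fluoro gives a 5.3-fold lower number from compound 2 to compound 4 (0.72 log units; beyond the scatter), beyond the scatter. Within the data shown here, the only earlier single-place step concerned the group on the aromatic nitrogen, so this is a second place where one change moves the number. No measurement shown accounts for this step.

As far as these compounds go, whether bromo, methyl or methoxy on this carbon would go further remains open. So does whether the step holds with pentan-3-yl on the aromatic nitrogen instead of cyclohexylmethyl.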